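This account rests on a few compounds, and the source may have more. Where it says the series, first, only, none or still open, it means among the compounds named here.

Measured in a functional assay on a cell-free system (plasma) for inhibition of thromboxane A2 receptor (Homo sapiens); a lower number here means a stronger inhibitor, a higher number a weaker inhibitor:
compound 1 `CSCSCC1C2CCC(O2)C1C/C=C\CCCC(=O)O` gives 700 nM
compound 2 `CCCCCCCCSCC1C2CCC(O2)C1C/C=C\CCCC(=O)O` gives 547000 nM
compound 3 `CCCCC(O)CSCC1C2CCC(O2)C1C/C=C\CCCC(=O)O` gives 19000 nM; 10000 nM (2 entries)

Compound 2 holds the highest of the two single numbers in this assay; compound 1 stands far lower, and compound 3, with its repeated entries (the several entries of compound 3 in this assay, 19000 nM; 10000 nM (2 entries)), sits between them without one single number. Compound 4 `CCCCCCCSCC1C2CCC(O2)C1C/C=C\CCCC(=O)O` differs from compound 2 by hydrogen in place of methyl on a saturated chain carbon, seven bonds along the chain from a sulfur. Going by the values given here, the only measured step that bears on this change is a 780-fold higher number from compound 1 to compound 2 (2.89 log units; beyond the scatter), a lengthening of the same sulfur-bound chain. The present change undoes a small part of that lengthening, so a modest move toward compound 1, a lower number in this assay, is expected, though it may not clear the scatter. The estimated change is a 2.7-fold lower number from compound 2 to compound 4 (0.44 log units; beyond the scatter). Compound 4 is therefore expected at 200000 nM, within 50000 nM to 700000 nM.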

Compound 4, half-maximal inhibitory concentration: 42000 nM
Compound 4: the middle estimate sits 4.8-fold (0.68 log units) above what was measured; the whole stated range lies above it.
By their numbers in this assay, from the lowest: compound 1; then compound 4; then compound 2.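

In this assay, hydrogen in place of methyl on a saturated chain carbon, seven bonds along the chain from a sulfur, gives a 13-fold lower number from compound 2 to compound 4 (1.11 log units; beyond the scatter), so the loss of a single carbon from this chain is a large change on its own. The shorter chain still stands well apart from the methylsulfanyl compound: exchanging that group for hexyl gives a 60-fold higher number from compound 1 to compound 4 (1.78 log units; beyond the scatter).

Going by these compounds, what an amine or a fluorine on this same carbon would do remains open. Nothing available here accounts for the size of the step from heptyl to hexyl.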